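The source may hold more compounds than are shown below. What is called first, only, known or untested is meant among the compounds shown, and "the series" means these compounds.

Measured compounds in a functional assay on MCF7 cells (Homo sapiens) for antiproliferative activity, read by MTT assay, with a stated time of 72 h; on this read-out lower numbers stand for stronger inhibition and higher numbers for weaker inhibition:
compound 1 `CC1=CC[C@H]2[C@H](CC[C@]2(C)O)C(C)(C)[C@@H]1CC[C@H]1[C@]2(C)CC[C@H](OCc3ccccc3)C(C)(C)O[C@H]2CC[C@@]1(C)O` gives a limit of the assay, > 50000 nM.
compound 2 `CC1=CC[C@H]2[C@H](CC[C@]2(C)O)C(C)(C)[C@@H]1CC[C@H]1[C@]2(C)CC[C@H](OC(=O)c3ccc([N+](=O)[O-])cc3)C(C)(C)O[C@H]2CC[C@@]1(C)O` gives 21600 nM.

For the measured compounds named here, compound 2 holds the only number in this assay; the other value shown is a limit and not a number. Going by the values given here, the only measured step is an at least 2.3-fold lower number from compound 1 to compound 2 (0.36 log units; beyond the scatter). Its size is known only as a lower bound because it rests on (the limit of > 50000 nM in this assay, at which 1 of the 2 values shown sits).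

Compound 3 `CC1=CC[C@H]2[C@H](CC[C@]2(C)O)C(C)(C)[C@@H]1CC[C@H]1[C@]2(C)CC[C@H](OC(=O)c3ccccc3Cl)C(C)(C)O[C@H]2CC[C@@]1(C)O` differs from compound 2 in one place: 2-chlorophenyl in place of 4-nitrophenyl on a carbonyl carbon. The measured step exchanged benzyl for an aryl carbonyl on an oxygen on a saturated carbon, so it does not test a swap between two aryl groups on the carbonyl carbon. Among the compounds with values here, no measured step bears directly on this change, and with a single number there is no basis for a direction. The expectation for compound 3 in this assay is therefore a 1.2-fold higher number from compound 2 to compound 3 (0.06 log units; within the scatter), a step not beyond the scatter either way. Compound 3 is estimated at 25000 nM, with a range of 9000 nM to 60000 nM.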

Compound 3, half-maximal inhibitory concentration: 12100 nM
Estimate against measurement, compound 3: 2.1-fold (0.32 log units) above; the measured number falls inside the stated range.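

In this assay, the exchange on the carbonyl carbon gives a 1.8-fold lower number from compound 2 to compound 3 (0.25 log units; within the scatter), so this place tolerates 2-chlorophenyl in place of 4-nitrophenyl without a change that can be read, even though the nitro group's nitrogen and oxygen atoms leave with it. A second aryl carbonyl group on the oxygen on a saturated carbon can now be set against benzyl, with an at least 4.1-fold lower number from compound 1 to compound 3 (0.61 log units; beyond the scatter), so compound 2 and compound 3 both differ from compound 1 in the same direction and none of the three compounds goes against this. The size of this step is known only as a lower bound because compound 1 gives a limit and not a number: the limit of > 50000 nM in this assay, at which 1 of the 3 values shown sits.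

The compounds shown do not separate the contribution of the carbonyl link from that of the ring substituents, a question that a plain phenyl on the carbonyl carbon or an acetyl group on the same oxygen would address. As far as these compounds go, how this place responds to a basic amine, a carboxylic acid or a longer alkyl chain also remains open.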